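The source may report more compounds than this note shows. Statements on the series, on what has been measured and on what is new or still open speak of the compounds shown alone.

Working notes on the series, read in a functional assay on A549 cells (Homo sapiens) for antiproliferative activity, read by MTT assay, with a stated time of 72 h; on this read-out lower numbers stand for stronger inhibition and higher numbers for weaker inhibition. Compound 1 `COc1ccc(SC(=S)N2CCN(C(=O)OC(C)(C)C)CC2)cc1` gives 712 nM. Compound 2 `CC(C)(C)OC(=O)N1CCN(C(=S)Sc2ccc(Br)cc2)CC1` gives 1820 nM. Compound 3 `CC(C)(C)OC(=O)N1CCN(C(=S)Sc2cccc(Cl)c2)CC1` gives 634 nM, which is within the scatter of compound 1 and lower than compound 2. Next comes compound 4 `CC(C)(C)OC(=O)N1CCN(C(=S)Sc2ccccc2Cl)CC1`, with 2-chlorophenyl in place of 3-chlorophenyl on a sulfur. Within the data shown here, no measured step moves the chlorine alone. The closest evidence is other exchanges on that sulfur: a 1.1-fold lower number from compound 1 to compound 3 (0.05 log units; within the scatter), a 2.9-fold lower number from compound 2 to compound 3 (0.46 log units; beyond the scatter) and a 2.6-fold higher number from compound 1 to compound 2 (0.41 log units; beyond the scatter). None exceeds modest size, so in this assay a small change, probably within the scatter, is expected, with no firm direction. The estimated step is a 1.3-fold higher number from compound 3 to compound 4 (0.10 log units; within the scatter). Compound 4 is estimated at 800 nM, with an expected range from 350 nM to 1900 nM.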

Compound 4, half-maximal inhibitory concentration: 1560 nM
Compound 4: the middle estimate sits 2.0-fold (0.29 log units) below what was measured; the measured number falls inside the stated range.
By their numbers in this assay, from the lowest: compounds 3 and 1 (each within the scatter of the next); then compounds 4 and 2 (each within the scatter of the next).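

In this assay, among these compounds, moving the chlorine alone is not neutral: 2-chlorophenyl in place of 3-chlorophenyl on a sulfur gives a 2.5-fold higher number from compound 3 to compound 4 (0.39 log units; beyond the scatter) with the atoms unchanged, the first such step. Against the other groups on that sulfur, the series shows a 1.2-fold lower number from compound 2 to compound 4 (0.07 log units; within the scatter) and a 2.2-fold higher number from compound 1 to compound 4 (0.34 log units; beyond the scatter) so compound 4 sits with compound 2 and apart from compound 1. No measurement shown explains the chlorine step.

Open, on these data alone, is how 4-chlorophenyl or a pyridyl group on that sulfur would compare with compound 3.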